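The source may report more compounds than this note shows. Statements on the series, on what has been measured and on what is new or still open speak of the compounds shown alone.

Measured so far:
- compound 1 `CCC(C)C(NC(=O)NO)C(=O)NC1CCCCC1`
- compound 2 `CC(C)C(NC(=O)NO)C(=O)NC1CCCC1`

In a functional assay on MCF7 cells (Homo sapiens) for inhibition (on this read-out higher numbers stand for weaker inhibition and lower numbers for stronger inhibition), compound 1 gives > 100000 nM, which is a limit of the assay and not a number. In this assay compound 2 gives > 100000 nM, likewise a limit of the assay rather than a measured number. Compound 2 therefore stands at the same limit as the other value shown (the limit of > 100000 nM in this assay, at which 2 of the 2 values shown sit). Within the data shown here, no step between measured compounds is available, so no size of effect for any structural change has been seen.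

Compound 3 `CCC(C)C(NC(=O)NO)C(=O)NC1CCCC1` differs from compound 2 by methyl in place of hydrogen on a saturated chain carbon, three bonds along the chain from an amide-type nitrogen and a carbonyl carbon. With both measured compounds sitting at the limit, the step that the limit leaves unreadable from compound 2 to compound 3 is expected to be none beyond the scatter. Compound 3 is estimated at 150000 nM, within 50000 nM to 500000 nM, and most probably this assay will again report only a limit for it.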

Compound 3, half-maximal inhibitory concentration: > 100000 nM
Compound 3 ended at the assay's limit (the forecaster's own chance of this, stated with the estimate: 85%); the middle value does not contradict the limit.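

No step can be read between compound 3 and either compound 1 or compound 2 in this assay, as all three stand at a limit of the assay and not at a number. The compounds shown leave open what size any of these structural changes has: the limit of > 100000 nM in this assay, at which 3 of the 3 values shown sit.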